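A 2-nitrophenyl swap on the sulfonyl sulfur

This account rests on a few compounds, and the source may have more. Where it says the series, first, only, none or still open, it means among the compounds named here.

compound 1 `COc1ccc(Cc2nnc(NC(=O)/C(C#N)=C/c3ccccc3OS(=O)(=O)c3ccccc3[N+](=O)[O-])s2)cc1`: 68%
compound 2 `Cc1ccc(S(=O)(=O)Oc2ccccc2/C=C(\C#N)C(=O)Nc2nnc(Cc3cccc(F)c3)s2)cc1`: 56%
compound 3 `COc1ccc(S(=O)(=O)Oc2ccccc2/C=C(\C#N)C(=O)Nc2nnc(Cc3cccc(F)c3)s2)cc1`: 74%

In a functional assay on RS4-11 cells (Homo sapiens) for inhibition, read by CCK-8 assay, with a stated time of 48 h, tested at 20 uM (a higher number here means more inhibition of growth at the concentration tested, a lower number less inhibition of growth), compound 3 gives 74%, a value within the scatter of compound 1. Going by the values given here, the one measured step in the set is a number 18 percentage points higher from compound 2 to compound 3 (beyond the scatter), so compound 3 stands clear of compound 2 only.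

Compound 4 `N#C/C(=C\c1ccccc1OS(=O)(=O)c1ccccc1[N+](=O)[O-])C(=O)Nc1nnc(Cc2cccc(F)c2)s1` keeps the rest of compound 3 and changes one group: 2-nitrophenyl in place of 4-methoxyphenyl on a sulfonyl sulfur. The measured step also concerns the aromatic ring on the sulfonyl sulfur, but it exchanges methyl for methoxy and says nothing directly about 2-nitrophenyl. The closest evidence is compound 1, which carries 2-nitrophenyl on a sulfonyl sulfur and gives 68%, although it differs from compound 4 elsewhere too. On that basis, no change beyond the scatter is expected in this assay. The expected step is a number 6 percentage points lower from compound 3 to compound 4 (within the scatter), which would be small. For compound 4 the estimate is 68%, with an expected range of 52% to 82%.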

Compound 4, percent growth inhibition at one concentration: 68%
For compound 4 middle estimate and measured number coincide at the digits printed; the range from low to high includes it.
By their numbers in this assay, from the lowest: compound 2; then compounds 1, 4 and 3 (each within the scatter of the next).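

With 2-nitrophenyl on the sulfonyl sulfur, this assay shows a number 6 percentage points lower from compound 3 to compound 4 (within the scatter) when it replaces 4-methoxyphenyl and a number 12 percentage points higher from compound 2 to compound 4 (beyond the scatter) when it replaces 4-methylphenyl, so this position accepts an aromatic ring carrying a nitro group and compound 4 stands with compound 3 and clear of compound 2. The other end of the molecule now has a matched pair as well: exchanging 4-methoxyphenyl for 3-fluorophenyl on a saturated chain carbon bound to an aromatic carbon gives no change at the digits printed from compound 1 to compound 4 (within the scatter) while 2-nitrophenyl stays in place. Nothing in the data given here accounts for these steps.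

The compounds shown leave open how an unsubstituted phenyl, an aminophenyl or a thiophene ring on the sulfonyl sulfur would read. They also leave open whether compounds 1, 3 and 4 would separate across a range of concentrations, since each has one reading at a single concentration.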